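A 3-bromobenzyl to 2,6-difluorobenzyl swap on one core

The source may report more compounds than this note shows. Statements on the series, on what has been measured and on what is new or still open speak of the compounds shown alone.

In a functional assay on SW 1116 cells (Homo sapiens) for antiproliferative activity, read by MTT assay, with a stated time of 48 h (on this read-out higher numbers stand for weaker inhibition and lower numbers for stronger inhibition), compound 1 (`Fc1ccc(CSc2nnc(-c3cnccn3)o2)c(F)c1`) gives 19300 nM, compound 2 (`c1ccc(CSc2nnc(-c3cnccn3)s2)cc1`) gives 7880 nM and compound 3 (`Brc1cccc(CSc2nnc(-c3cnccn3)n2-c2ccccc2)c1`) gives 5030 nM. Compound 3 sits level with compound 2 within the usual scatter, while compound 1 reads higher than compound 3, beyond that scatter. Compound 4 (`Fc1cccc(F)c1CSc1nnc(-c2cnccn2)n1-c1ccccc1`) carries 2,6-difluorophenyl in place of 3-bromophenyl on a saturated chain carbon bound to a sulfur. Among the compounds with values here, no measured pair isolates this change. Within the data shown here, the only fluorinated compound measured, compound 1, has a different core and reads 19300 nM, so a modest rise in this assay is expected, a 1.8-fold higher number from compound 3 to compound 4 (0.25 log units; within the scatter). Compound 4 is estimated at 9000 nM, with an expected range of 3500 nM to 24000 nM.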

Compound 4, half-maximal inhibitory concentration: 24100 nM
Compound 4: middle estimate off by 2.7-fold (0.43 log units), on the low side; the measured number lies above the stated range.
By their numbers in this assay, from the lowest: compounds 3 and 2 (each within the scatter of the next); then compounds 1 and 4 (each within the scatter of the next).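

Within the data shown here, the step of a 4.8-fold higher number from compound 3 to compound 4 (0.68 log units; beyond the scatter) in this assay is the first reading of a single change on one core, and it goes beyond the scatter. At this saturated chain carbon bound to a sulfur, 2,6-difluorophenyl therefore gives weaker inhibition than 3-bromophenyl, so the aryl group here affects the read-out. Nothing measured on these compounds accounts for the rise. The compounds shown leave open whether the rise follows the loss of bromine or the arrival of fluorine. They also leave open how a methoxy group or a carboxylic acid on that phenyl ring would read.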